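The source may report more compounds than this note shows. Statements on the series, on what has been measured and on what is new or still open speak of the compounds shown alone.

Values measured in a functional assay on MC-38 cells (Mus musculus) for antiproliferative activity, read by CCK-8 assay, with a stated time of 72 h (a higher number here means a weaker inhibitor of growth, a lower number a stronger inhibitor of growth), as follows

- compound 1 `Nc1nc(NCc2ccc(OCCCCC(=O)NO)cc2)nc2nc(-c3ccco3)nn12` gives "not determined" (no result reported) as its entry
- compound 2 `Nc1nc(NCCOc2ccc(C(=O)NO)cc2)nc2nc(-c3ccco3)nn12` gives > 100000 nM as a limit

Compound 2 stands at the limit of > 100000 nM in this assay, at which 1 of the 2 values shown sits, and has no single number. Compound 3 `Nc1ccccc1NC(=O)c1ccc(OCCNc2nc(N)n3nc(-c4ccco4)nc3n2)cc1` differs from compound 2 by 2-aminophenyl in place of hydroxy on an amide-type nitrogen and so carries 2-aminophenyl in place of hydroxy on an amide-type nitrogen. Within the data shown here, no measured step covers this change. The expected change is a number no higher from compound 2 to compound 3 (the limit leaves the size open) and amounts to no step beyond the scatter in either direction in this assay, and another limit is more likely than a number. Compound 3 is estimated at 100000 nM with an expected range from 20000 nM to 300000 nM as its upper end.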

Compound 3, concentration for 50% growth inhibition: 36900 nM
For compound 3 the middle estimate is 2.7-fold (0.43 log units) above the measured one; low and high end bracket the measured number.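

In this assay, the change from hydroxy to 2-aminophenyl on the amide-type nitrogen gives an at least 2.7-fold lower number from compound 2 to compound 3 (0.43 log units; beyond the scatter), so this position accepts the larger aromatic group and the series gains its first single number. Compound 3 therefore sets a measured reference for further changes at this nitrogen. The value of compound 2 is a limit and not a number, so the full size of the step stays unknown: the limit of > 100000 nM in this assay, at which 1 of the 3 values shown sits.

On these data alone, what a plain phenyl or a methyl on the same nitrogen would give stays open. So does whether 2-aminophenyl gives a similar step on a longer chain.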